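From Phenylsulfonylamino to Carboxy: Expecting Compound 4

The source may hold more compounds than are shown below. What is called first, only, known or untested is meant among the compounds shown, and "the series" means these compounds.

Compound 1 `CCCNc1cccnc1-c1ccc(C(=O)Nc2ccc(C(C)(C)C)cc2)cc1`: 37 nM
Compound 2 `CC(C)(C)c1ccc(NC(=O)c2ccc(-c3ncccc3NC3CCCC3)cc2)cc1`: 44 nM
Compound 3 `CC(C)(C)c1ccc(NC(=O)c2ccc(-c3ncccc3NS(=O)(=O)c3ccccc3)cc2)cc1`: 166 nM

In a functional assay for antagonist activity at transient receptor potential cation channel subfamily V member 1 (Rattus norvegicus) (on this read-out higher numbers stand for weaker inhibition and lower numbers for stronger inhibition), compound 3 gives the highest number of the three measured compounds; both a 4.5-fold higher number from compound 1 to compound 3 (0.65 log units; beyond the scatter) and a 3.8-fold higher number from compound 2 to compound 3 (0.58 log units; beyond the scatter) lie beyond the scatter, while a 1.2-fold higher number from compound 1 to compound 2 (0.08 log units; within the scatter) does not. Compound 4 `CC(C)(C)c1ccc(NC(=O)c2ccc(-c3ncccc3C(=O)O)cc2)cc1` differs from compound 3 by carboxy in place of (phenylsulfonyl)amino on an aromatic carbon. Every measured step only exchanges one substituent on the nitrogen of the shared core for another, so none of them speaks directly to removing that nitrogen and placing a carboxy group there. The expectation therefore rests on compound 3 alone, with a wide range on either side and a modest further rise in this assay as the most plausible outcome. Compound 4 is expected to give 600 nM, between 120 nM and 4000 nM, an estimated step of a 3.6-fold higher number from compound 3 to compound 4 (0.56 log units; beyond the scatter).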

Compound 4, half-maximal inhibitory concentration: 560 nM
For compound 4 the middle estimate is 1.1-fold (0.03 log units) above the measured one, within the range that was stated.
By their numbers in this assay, from the lowest: compounds 1 and 2 (each within the scatter of the next); then compound 3; then compound 4.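

In this assay carboxy on this aromatic carbon gives a higher number than each of the three amino groups it replaces (a 3.4-fold higher number from compound 3 to compound 4 (0.53 log units; beyond the scatter); a 13-fold higher number from compound 2 to compound 4 (1.10 log units; beyond the scatter); a 15-fold higher number from compound 1 to compound 4 (1.18 log units; beyond the scatter)). The earlier compounds shown here changed only what the nitrogen carries, whereas this change removes that nitrogen as well, and the steps from propylamino and cyclopentylamino are the large ones. Nothing available here explains the rise.

As far as these compounds go, how a methyl ester or a hydroxymethyl group on this carbon would compare with carboxy stays open. So does the effect of a longer chain on the nitrogen.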